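The compounds below may be only part of what the source reports. "The series", "measured", "known", "first", "only" and "open" are said of these compounds alone.

Working notes on the series.

Of the compounds shown here, three of the shared core have been measured in a functional assay on NCI-H460 cells (Homo sapiens) for cytotoxicity, read by MTT assay, with a stated time of 72 h; on this read-out lower numbers stand for stronger inhibition and higher numbers for weaker inhibition. Compound 1 `COc1cc2c(Oc3ccc(NC(=O)c4cn(-c5ccccc5)nn4)cc3F)ccnc2cc1OCCCN1CCC(C)CC1` gives 210 nM. Compound 2 `COc1cc2c(Oc3ccc(NC(=O)c4cn(-c5ccccc5Cl)nn4)cc3F)ccnc2cc1OCCCN1CCC(C)CC1` gives 230 nM. Compound 3 `COc1cc2c(Oc3ccc(NC(=O)c4cn(-c5ccccc5C)nn4)cc3F)ccnc2cc1OCCCN1CCC(C)CC1` gives 2730 nM, the highest of the three numbers; its nearest neighbour is compound 2 and its furthest is compound 1. Among the single-site steps, a 1.1-fold higher number from compound 1 to compound 2 (0.04 log units; within the scatter), whereas a 13-fold higher number from compound 1 to compound 3 (1.11 log units; beyond the scatter) and a 12-fold higher number from compound 2 to compound 3 (1.07 log units; beyond the scatter).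

Compound 4 `COc1cc2c(Oc3ccc(NC(=O)c4cn(-c5c(C)cccc5C)nn4)cc3F)ccnc2cc1OCCCN1CCC(C)CC1` is not yet measured. Against compound 3 the change is methyl in place of hydrogen on an aromatic carbon, a second methyl at the same kind of position as the first, so that the 2-methylphenyl becomes 2,6-dimethylphenyl. Among the compounds with values here, the steps that bear on it are those into compound 3: the first methyl in place of hydrogen moved the number a long way, as seen in a 13-fold higher number from compound 1 to compound 3 (1.11 log units; beyond the scatter) and a 12-fold higher number from compound 2 to compound 3 (1.07 log units; beyond the scatter). A second methyl of the same kind is therefore expected to move this assay further in the same direction, though how far a repeat of the change carries is not shown by the measured compounds; a step smaller than the first is assumed. The expected step is a 2.2-fold higher number from compound 3 to compound 4 (0.34 log units; beyond the scatter). For compound 4 the estimate in this assay is 6000 nM, with a range of 1800 nM to 20000 nM.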

Compound 4, half-maximal inhibitory concentration: 2360 nM
Compound 4: middle estimate off by 2.5-fold (0.41 log units), on the high side; the measured number falls inside the stated range.
By their numbers in this assay, from the lowest: compounds 1 and 2 (each within the scatter of the next); then compounds 4 and 3 (each within the scatter of the next).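

In this assay a second methyl on this ring cannot be told apart from the first, with a 1.2-fold lower number from compound 3 to compound 4 (0.06 log units; within the scatter) within the scatter, so at this position the repeat of the change does not carry the number further. The large gap to the unsubstituted phenyl and to the 2-chlorophenyl remains in place with the 2,6-dimethylphenyl, as an 11-fold higher number from compound 1 to compound 4 (1.05 log units; beyond the scatter) and a 10-fold higher number from compound 2 to compound 4 (1.01 log units; beyond the scatter) show, so a single methyl already accounts for the whole gap among these compounds and the second adds nothing measurable, while the chloro of compound 2 stands against any reading that treats all groups at this place alike. No measurement at hand explains this flat step or the gap between methyl and chloro.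

Still open, from the compounds shown here alone, is whether a second chloro, as in 2,6-dichlorophenyl, would stay with compound 2 or fall with compound 3 and compound 4. Also open, going by these compounds, is how a methoxy, an ethyl or an amine would read on this ring, and so whether the large step belongs to methyl alone or to a wider set of groups.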